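Swapping the aryl group on sulfur in a labdane-type lactone

The source may hold more compounds than are shown below. What is called first, only, known or untested is meant among the compounds shown, and "the series" means these compounds.

Of the compounds shown here, three sharing one core have been tested in a functional assay on PC-3 cells (Homo sapiens) for inhibition, read by MTT assay, with a stated time of 48 h; on this read-out higher numbers stand for weaker inhibition and lower numbers for stronger inhibition. Compound 1 `C=C1CC[C@@H]2[C@](C)(CO)[C@H](O)CC[C@@]2(C)[C@@H]1CC(Sc1ccccc1)C1=CCOC1=O` carries a phenyl group on the sulfur, and in this assay compound 1 gives 14000 nM. Compound 2 `C=C1CC[C@@H]2[C@](C)(CO)[C@H](O)CC[C@@]2(C)[C@@H]1CC(Sc1ccc([N+](=O)[O-])cc1)C1=CCOC1=O` has a nitro in place of hydrogen on an aromatic carbon, and compound 2 gives 17000 nM. Compound 3 `C=C1CC[C@@H]2[C@](C)(CO)[C@H](O)CC[C@@]2(C)[C@@H]1CC(Sc1ccccn1)C1=CCOC1=O` has a pyridin-2-yl in place of phenyl on the sulfur, and compound 3 gives 18000 nM. The steps of a 1.2-fold higher number from compound 1 to compound 2 (0.08 log units; within the scatter) and a 1.3-fold higher number from compound 1 to compound 3 (0.11 log units; within the scatter) are both within the scatter, as is a 1.1-fold higher number from compound 2 to compound 3 (0.02 log units; within the scatter), so compound 3 sits alongside the other two rather than apart from them.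

Compound 4 `C=C1CC[C@@H]2[C@](C)(CO)[C@H](O)CC[C@@]2(C)[C@@H]1CC(Sc1nccs1)C1=CCOC1=O` continues this series: 1,3-thiazol-2-yl in place of pyridin-2-yl on a sulfur. The two steps that bear on such a change at the sulfur, a 1.3-fold higher number from compound 1 to compound 3 (0.11 log units; within the scatter) and a 1.1-fold higher number from compound 2 to compound 3 (0.02 log units; within the scatter), were both small, so no step beyond the scatter is expected here either, in either direction. For compound 4 the estimate in this assay is therefore 17000 nM, within a range from 8000 nM to 40000 nM, which means an expected step of a 1.1-fold lower number from compound 3 to compound 4 (0.02 log units; within the scatter).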

Compound 4, half-maximal inhibitory concentration: 14000 nM
Estimate against measurement, compound 4: 1.2-fold (0.08 log units) above, and the stated range covers the measured number.
By their numbers in this assay, from the lowest: compounds 1, 4, 2 and 3 (each within the scatter of the next).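

In this assay, a five-membered aromatic ring on the sulfur gives a number that cannot be told apart from those of the six-membered rings. This holds against all three earlier compounds: a 1.3-fold lower number from compound 3 to compound 4 (0.11 log units; within the scatter) and a 1.2-fold lower number from compound 2 to compound 4 (0.08 log units; within the scatter) and also no change at the digits printed from compound 1 to compound 4 (within the scatter). Among these four compounds, then, 1,3-thiazol-2-yl on the sulfur, with its smaller ring and its second hetero atom, brings no step beyond the scatter, and nothing measured here accounts for this flat result.

As far as these compounds go, whether a saturated chain such as hexyl on the sulfur, or an aromatic ring carrying an amine or a carboxylic acid, would give a step beyond the scatter stays open. So does the question of whether a change at the hydroxymethyl group of the shared core would matter more than the group on the sulfur.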